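This account rests on a few compounds, and the source may have more. Where it says the series, first, only, none or still open, it means among the compounds named here.

Compound 1 `Cc1ccc(Nc2nccc(-c3ccnc4ccccc34)n2)cc1`: 100%
Compound 2 `FC(F)(F)c1ccc(Nc2nccc(-c3ccnc4ccccc34)n2)cc1`: 100%
Compound 3 `Cc1ccc(Nc2nccc(-c3c(C)nc4ccccn34)n2)cc1`: 95.2%

In a functional assay on HCT-15 cells (Homo sapiens) for cytotoxicity, read by sulforhodamine B assay, with a stated time of 48 h, tested at 50 uM (on this read-out lower numbers stand for less inhibition and higher numbers for more inhibition at the one concentration tested (going by the name of the read-out)), compound 1 and compound 2 both reach the full value shown above, and compound 3 lies within the scatter of them. The change trifluoromethyl in place of methyl on an aromatic carbon gave the step of no change at the digits printed from compound 1 to compound 2 (within the scatter). Compound 4 `Cc1nc2ccccn2c1-c1ccnc(Nc2ccc(C(F)(F)F)cc2)n1` carries the same change on the core of compound 3, namely (trifluoromethyl in place of methyl on an aromatic carbon); how the core of compound 3 differs from the core of compound 1 is not broken down here. Because the step of no change at the digits printed from compound 1 to compound 2 (within the scatter) stayed within the scatter and compound 3 already sits near the top of the read-out with 95.2%, the step from compound 3 to compound 4 is expected to be a number 1.8 percentage points higher from compound 3 to compound 4 (within the scatter) in this assay. Compound 4 is therefore estimated at 97%, between 85% and 100%.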

Compound 4, a percentage reported as inhibition, at one concentration (the size of the read-out at that concentration, not a potency): 88.6%
Estimate against measurement, compound 4: 8.4 percentage points above, and the stated range covers the measured number.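

In this assay the replacement of methyl by trifluoromethyl on an aromatic carbon gives a number 6.6 percentage points lower from compound 3 to compound 4 (within the scatter) and so does not separate the two compounds. Set beside the earlier step, the change reads alike on both cores: the same change on two cores in this assay, no change at the digits printed (within the scatter) from compound 1 to compound 2 and a number 6.6 percentage points lower (within the scatter) from compound 3 to compound 4, 6.6 percentage points apart, within the scatter of two such steps. This shows that no dependence on the core can be seen for this change at the one concentration tested, but it does not show that the change is neutral on other cores or that potency is unaffected, since two pairs measured at a single concentration cannot show either.

Going by these compounds, what an amine, a nitrile or a carboxylic acid at this place would give on either core remains open. So does how these compounds would compare at other concentrations.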